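The source may report more compounds than this note shows. Statements on the series, on what has been measured and on what is new or still open speak of the compounds shown alone.

Working notes on the series. In an ADME assay on MDCK cells (Canis lupus familiaris) for cytotoxicity, read by microscopy, with a stated time of 48 h (on this read-out higher numbers stand for lower toxicity in this test and lower numbers for higher toxicity in this test), compound 1 `C[C@H]1[C@H](NCc2ccc(C(C)(C)C)s2)C[C@H]2C[C@@H]1C2(C)C` gives 780 nM. Compound 2 `CCc1ccc(CN[C@@H]2C[C@H]3C[C@@H]([C@H]2C)C3(C)C)s1` gives 1560 nM in this assay. For the measured compounds named here, on the two numbers so far compound 2 holds the higher one, with compound 1 as its nearest neighbour, but the gap between them lies within the scatter, so the two cannot be told apart.

Going by the values given here, compound 3 `C[C@H]1[C@H](NCc2ccc(Br)s2)C[C@H]2C[C@@H]1C2(C)C` is the next one for this assay. bromo in place of ethyl on an aromatic carbon Only one measured step bears on this change: a 2.0-fold higher number from compound 1 to compound 2 (0.30 log units; within the scatter), which also exchanged the group on this same aromatic carbon of the five-membered aromatic ring with 1 sulfur and lay within the scatter. Among the compounds with values here, no measured step replaces an alkyl group with a halogen, so the bromo group itself has no precedent. On that basis the expectation in this assay is for no step beyond the scatter, the expected step being a 1.3-fold lower number from compound 2 to compound 3 (0.11 log units; within the scatter). Compound 3 is therefore estimated at 1200 nM, with a range from 400 nM to 4000 nM.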

Compound 3, minimum cytotoxic concentration: 43000 nM
Compound 3: the middle estimate sits 36-fold (1.55 log units) below what was measured; the whole stated range lies below it.
By their numbers in this assay, from the lowest: compounds 1 and 2 (each within the scatter of the next); then compound 3.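

In this assay, the group on this aromatic carbon next to the ring sulfur can move the read-out far beyond the scatter: bromo in place of ethyl gives (a 28-fold higher number from compound 2 to compound 3 (1.44 log units; beyond the scatter)), and bromo in place of tert-butyl gives (a 55-fold higher number from compound 1 to compound 3 (1.74 log units; beyond the scatter)). The only earlier exchange at this carbon, between the two alkyl groups, stayed within the scatter (a 2.0-fold higher number from compound 1 to compound 2 (0.30 log units; within the scatter)), so among these three compounds the large steps appear only with bromo, and both point towards lower toxicity in this test. Nothing at hand accounts for the size of these steps.

Going by these compounds, it remains open whether this large step belongs to bromo alone or would also appear with chloro, fluoro or a nitrile on the same carbon, and whether an amine or a carboxylic acid there would fall with the alkyl groups or with bromo. Also open, on these data alone, is whether bromo would give a step of this size on a different core, since all three compounds share the core of compound 1.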